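A few compounds are considered here, and "the series" means these few. Any claim that something is new, unique, unknown or untested is made for them only; others in the source may bear on it.

Going by the values given here, compound 2, `Cc1cc(C#N)cc(C)c1Oc1ccc(N)c(Nc2ccc(C#N)cc2)c1`, is one of two compounds measured in an ADME assay on H9 cells (Homo sapiens) for cytotoxicity, read by XTT assay, with a stated time of 6 days; on this read-out higher numbers stand for lower toxicity in this test and lower numbers for higher toxicity in this test. In this assay compound 2 gives 49800 nM, and it stands level with compound 1, `Cc1cc(C)c(Oc2ccc(N)c(Nc3ccc(C#N)cc3)c2)c(C)c1`, which in this assay gives 51000 nM; the step of a 1.0-fold lower number from compound 1 to compound 2 (0.01 log units; within the scatter) shows that the two numbers are indistinguishable on this read-out.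

The next compound, compound 3, `Cc1cc(C#N)cc(C)c1Oc1cc(Nc2ccc(C#N)cc2)c(N)cc1N`, has not yet been measured in this assay. Its change from compound 2 is amino in place of hydrogen on an aromatic carbon.

Among the compounds with values here, only one measured step exists, the one from compound 1 to compound 2, and it concerns a different change, cyano in place of methyl, so it offers no direct parallel to the entry of an amino group. It does show that one alteration on the shared core left the number in this assay unchanged within the scatter. With no closer guide, the expected step for compound 3 is a 1.1-fold lower number from compound 2 to compound 3 (0.04 log units; within the scatter), that is, none beyond the scatter. Compound 3 is therefore estimated at 45000 nM in this assay, with a range from 18000 nM to 110000 nM.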

Compound 3, half-maximal cytotoxic concentration: 51000 nM
Compound 3: the middle estimate sits 1.1-fold (0.05 log units) below what was measured; measured number inside the range.
By their numbers in this assay, from the lowest: compounds 2, 1 and 3 (each within the scatter of the next).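

Amino in place of hydrogen, on an aromatic carbon para to a (4-cyanophenyl)amino group and ortho to a large group, gives a 1.0-fold higher number from compound 2 to compound 3 (0.01 log units; within the scatter) in this assay, so compound 2 and compound 3 stand level on this read-out. The earlier step concerned cyano in place of methyl at a different place on the shared core, whereas this one shows that a second place on that core also accepts a new group with the number staying within the scatter, and here the group enters where only a hydrogen stood. Nothing available accounts for this level result at this position.

The compounds shown leave open whether this position would stay level with another group in place of the amino group, such as a hydroxyl, a methoxy, an acetamide or a carboxylic acid, since amino is the only group seen here. They also leave open whether a dimethylamino group or a longer chain on that nitrogen would keep the number level in this assay, and whether the same holds with the methyl groups of compound 1 in place of the cyano of compound 3.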